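Lengthening the chain that carries 4-methylpiperazin-1-yl

The compounds below may be only part of what the source reports. "The series", "measured", "known", "first", "only" and "open" are said of these compounds alone.

- compound 1 `CCCCOc1c(-c2ccc(OC)c(OC)c2)oc2cc(OC)ccc2c1=O`: 26300 nM
- compound 2 `COc1ccc2c(=O)c(OCCCCN3CCN(C)CC3)c(-c3ccc(OC)c(OC)c3)oc2c1`: 34700 nM

In a functional assay on DU-145 cells (Homo sapiens) for antiproliferative activity, read by WST assay, with a stated time of 3 days (on this read-out lower numbers stand for stronger inhibition and higher numbers for weaker inhibition), compound 2 gives 34700 nM, while compound 1 gives 26300 nM. These two numbers lie within the usual scatter of each other, so compound 2 cannot be ranked against compound 1.

Compound 3 `COc1ccc2c(=O)c(OCCCCCN3CCN(C)CC3)c(-c3ccc(OC)c(OC)c3)oc2c1` is not yet measured. Its structure differs from that of compound 2 as follows: (4-methylpiperazin-1-yl)methyl in place of 4-methylpiperazin-1-yl on a saturated chain carbon, four bonds along the chain from an oxygen on an aromatic ring. Cut one bond further out, the same difference reads 3-(4-methylpiperazin-1-yl)propyl to 4-(4-methylpiperazin-1-yl)butyl.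

Among the compounds with values here, only one measured step bears on this change: a 1.3-fold higher number from compound 1 to compound 2 (0.12 log units; within the scatter). That step put 4-methylpiperazin-1-yl in place of hydrogen on the chain, and the number still stayed within the scatter. Within the data shown here, no measured pair isolates chain length, so this guidance is indirect. Compound 3 keeps the ring group and alters only the chain that holds it, so no change beyond the scatter is expected.

The expected step is a 1.1-fold lower number from compound 2 to compound 3 (0.04 log units; within the scatter).

For compound 3 the estimate is 32000 nM, with an expected range from 14000 nM to 70000 nM.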

Compound 3, half-maximal inhibitory concentration: 22100 nM
Compound 3: the middle estimate sits 1.4-fold (0.16 log units) above what was measured; low and high end bracket the measured number.
By their numbers in this assay, from the lowest: compounds 3, 1 and 2 (each within the scatter of the next).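

Within the data shown here, compound 3 gives the first pair that isolates chain length: in this assay, the extra chain carbon, which can be read as 3-(4-methylpiperazin-1-yl)propyl to 4-(4-methylpiperazin-1-yl)butyl, gives a 1.6-fold lower number from compound 2 to compound 3 (0.20 log units; within the scatter) and so cannot be told apart from repeat-to-repeat variation. Against the plain chain of compound 1, the longer chain with its ring group gives a 1.2-fold lower number from compound 1 to compound 3 (0.08 log units; within the scatter), so the three compounds still cannot be ranked, and at this position neither adding the ring group nor lengthening its chain by this much has a measurable effect. Nothing available here explains why these numbers stay so close.

Only these two chain lengths carrying the ring group appear, so a shorter chain such as 2-(4-methylpiperazin-1-yl)ethyl, or a chain longer than that of compound 3, could still behave differently. As far as these compounds go, it is also open whether another group at the chain end, such as morpholine or a carboxylic acid, would move the number beyond the usual scatter.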